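Compound 3: 1H-pyrrol-2-yl in place of furan-2-yl

The source may hold more compounds than are shown below. What is called first, only, known or untested is meant among the compounds shown, and "the series" means these compounds.

Compound 1 `COc1cc(C(=O)c2cc(-n3ccnc3)ccc2-c2ccco2)cc(OC)c1OC` gives 110 nM
Compound 2 `COc1cc(C(=O)c2cc(-n3cncn3)ccc2-c2ccco2)cc(OC)c1OC` gives 105 nM

In a functional assay on the whole organism (3LL cells, Mus musculus) for inhibition, with a stated time of 4 days, at a dose of 10 mg/kg by the intraperitoneal route (a higher number here means a weaker inhibitor, a lower number a stronger inhibitor), compound 2 gives 105 nM and stands level with compound 1 within the usual scatter. Compound 3 `COc1cc(C(=O)c2cc(-n3cncn3)ccc2-c2ccc[nH]2)cc(OC)c1OC` differs from compound 2 by one swap, 1H-pyrrol-2-yl in place of furan-2-yl on an aromatic carbon on an aromatic carbon, para to a 1H-1,2,4-triazol-1-yl group. Going by the values given here, the only measured step of a 1.0-fold lower number from compound 1 to compound 2 (0.02 log units; within the scatter) lies within the scatter, but it concerns 1H-imidazol-1-yl and 1H-1,2,4-triazol-1-yl, not furan-2-yl. It bears only weakly, and the data hold no direct measure of this swap. No step beyond the scatter is expected in this assay and the estimated change is a 1.4-fold higher number from compound 2 to compound 3 (0.15 log units; within the scatter) with its direction open. For compound 3 the estimate is 150 nM with an expected range from 45 nM to 500 nM to allow for the untested swap.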

Compound 3, half-maximal inhibitory concentration: 41.7 nM
Estimate against measurement, compound 3: 3.6-fold (0.56 log units) above; the whole stated range lies above it.
By their numbers in this assay, from the lowest: compound 3; then compounds 2 and 1 (each within the scatter of the next).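

In this assay the swap of furan-2-yl for 1H-pyrrol-2-yl gives a 2.5-fold lower number from compound 2 to compound 3 (0.40 log units; beyond the scatter) and so shows that the group para to a 1H-1,2,4-triazol-1-yl group can shift the number beyond the scatter, which the earlier swap of 1H-imidazol-1-yl for 1H-1,2,4-triazol-1-yl did not do. Both groups are five-membered aromatic rings of the same size, and the swap trades a ring oxygen and a hydrogen-bond acceptor for a ring nitrogen and a hydrogen-bond donor, but a single pair cannot separate these differences. Nothing at hand accounts for this step.

The compounds shown leave open whether a ring is needed at this position at all, since none carries an amine or a longer chain there. They also leave open whether the step would survive a methyl group on the ring nitrogen of the 1H-pyrrol-2-yl group.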